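The source may report more compounds than this note shows. Statements on the series, on what has been measured and on what is new or still open speak of the compounds shown alone.

Of the compounds shown here, three have been measured in a functional assay, with a stated time of 10 min; on this read-out higher numbers stand for weaker inhibition and lower numbers for stronger inhibition. Compound 1 `COc1ccc(-c2nc(NN)n(C)c(=O)c2C#N)cc1` gives 32 ug/mL, compound 2 `CCOC(=O)c1cnn(-c2nc(-c3cccc(OC)c3OC)c(C#N)c(=O)n2C)c1N` gives 67 ug/mL and compound 3 `CN(C)c1ccc(-c2nc(NN)n(C)c(=O)c2C#N)cc1` gives 66 ug/mL. Compound 3 thus stands at the second-highest of the three numbers; its value and that of compound 2 lie within the scatter of each other, while the step of a 2.1-fold higher number from compound 1 to compound 3 (0.31 log units; beyond the scatter) lies beyond the scatter. Compound 4 `Cn1c(NN)nc(-c2ccc(Cl)cc2)c(C#N)c1=O` carries the change (chloro in place of dimethylamino on an aromatic carbon). Within the data shown here, no measured step introduces a chloro group, so the one step that bears on this position is the modest one a 2.1-fold higher number from compound 1 to compound 3 (0.31 log units; beyond the scatter), which shows that exchanging the group on this aromatic carbon shifts the read-out by a modest amount and in a direction that cannot be read from a single pair. Compound 4 is therefore expected to move by a 1.5-fold lower number from compound 3 to compound 4 (0.17 log units; within the scatter), a small drift back toward the number of compound 1 with wide uncertainty. The estimate for compound 4 in this assay is 45 ug/mL, with a range from 18 ug/mL to 110 ug/mL.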

Compound 4, half-maximal inhibitory concentration: 41 ug/mL
The estimate for compound 4 lay 1.1-fold (0.04 log units) above the measured number; measured number inside the range.
By their numbers in this assay, from the lowest: compounds 1, 4, 3 and 2 (each within the scatter of the next, the first and the last beyond it).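

In this assay, among these compounds, chloro is the first replacement at this position that stays within the scatter of its neighbours: a 1.6-fold lower number from compound 3 to compound 4 (0.21 log units; within the scatter), and a 1.3-fold higher number from compound 1 to compound 4 (0.11 log units; within the scatter). Chloro, with 1 heavy atom and 0 hydrogen-bond acceptors, thus takes the place of dimethylamino, with 3 heavy atoms and 1 hydrogen-bond acceptor, without a shift beyond the scatter, so neither the larger size nor the acceptor is needed on this aromatic carbon to keep the number in this range. No measurement is available that would explain this result.

As far as these compounds go, it remains open whether a carboxylic acid, a primary amine or a longer alkyl chain on this carbon would move the number beyond the scatter. From the compounds shown here alone, it is also open whether chloro would read the same at another carbon of this ring.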